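Swapping isopropyl for cyclopropyl in a lactam aldehyde series

The source may report more compounds than this note shows. Statements on the series, on what has been measured and on what is new or still open speak of the compounds shown alone.

Three compounds share a core built around a lactam ring and a terminal aldehyde, and all three were tested in an ADME assay on Vero C1008 cells (Chlorocebus sabaeus) for cytotoxicity, read by luminescence and CellTiter-Glo, with a stated time of 24 h; on this read-out higher numbers stand for lower toxicity in this test and lower numbers for higher toxicity in this test. Compound 1 `O=C[C@H](C[C@@H]1CCNC1=O)NC(=O)[C@H](CC1CC1)NC(=O)OCc1ccccc1` carries a cyclopropylmethyl side chain and an unsubstituted benzyl carbamate. In this assay compound 1 gives > 200000 nM, which is a limit of the assay. Compound 2 `CC(C)C[C@H](NC(=O)OCc1cccc(F)c1)C(=O)N[C@H](C=O)C[C@@H]1CCNC1=O` carries an isobutyl side chain and a 3-fluorophenyl carbamate. In this assay compound 2 gives > 200000 nM, again a limit. Compound 3 `CC(C)C[C@H](NC(=O)OCCc1cccc(Cl)c1)C(=O)N[C@H](C=O)C[C@@H]1CCNC1=O` gives > 200000 nM in this assay, also a limit. Going by the values given here, the single measured step, a step that the two limits leave unreadable from compound 2 to compound 3, therefore cannot be read, and the only evidence is the limit of > 200000 nM in this assay, at which 3 of the 3 values shown sit.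

Compound 4 `O=C[C@H](C[C@@H]1CCNC1=O)NC(=O)[C@H](CC1CC1)NC(=O)OCc1cccc(F)c1` differs from compound 2 by one change: cyclopropyl in place of isopropyl on a saturated chain carbon, two bonds along the chain from an amide-type nitrogen and a carbonyl carbon. Among the compounds with values here, no measured step bears directly on this change, so nothing in the data points to a shift in either direction beyond the scatter. Because compound 1 already sits at the limit with > 200000 nM while carrying the same cyclopropylmethyl chain, compound 4 is expected to remain at or beyond the same limit, with the estimated step of a number no higher from compound 2 to compound 4 (the limit leaves the size open). The estimate for compound 4 is 200000 nM, between 100000 nM and 400000 nM.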

Compound 4, half-maximal cytotoxic concentration: > 200000 nM
Compound 4: a limit, no number (the forecaster's own chance of this, stated with the estimate: 85%); the middle value sits exactly at the limit.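

Neither the step between compound 2 and compound 4 nor the step between compound 1 and compound 4 can be read, as both ends of each are limits, not numbers: the limit of > 200000 nM in this assay, at which 4 of the 4 values shown sit.

The compounds shown leave open whether cyclopropyl in place of isopropyl, or fluoro in place of hydrogen on an aromatic carbon, changes toxicity in this test at all.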